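Acetyl in place of methoxy, seen a second time

The source may hold more compounds than are shown below. What is called first, only, known or untested is meant among the compounds shown, and "the series" means these compounds.

Of the compounds shown here, three have been measured in an ADME assay on the whole organism with Oryza sativa as the target, tested at 0.1 uM; on this read-out higher numbers stand for a weaker effect at the one concentration tested and lower numbers for a stronger effect. Compound 1 `COc1ccccc1NC(=O)N[C@@H](C)c1ccccc1` gives 98% in this assay, compound 2 `COc1cccc(NC(=O)N[C@H](C)c2ccccc2)c1` gives 104%, and compound 3 `CC(=O)c1ccccc1NC(=O)N[C@@H](C)c1ccccc1` gives 100%. Compounds 1 and 3 differ in one place, (acetyl in place of methoxy on an aromatic carbon), and this gave a number 2 percentage points higher from compound 1 to compound 3 (within the scatter) in this assay. Compound 2 and compound 1 are built from the same atoms joined differently; the difference between the two cores is not broken down here.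

Compound 4 `CC(=O)c1cccc(NC(=O)N[C@H](C)c2ccccc2)c1` has not yet been measured in this assay. It differs from compound 2 by acetyl in place of methoxy on an aromatic carbon. Around the place there is a difference: in compound 1 the group sits ortho to a large group, in compound 2 meta to a large group, so this is the same kind of change, not the same change.

Because the earlier change gave a number 2 percentage points higher from compound 1 to compound 3 (within the scatter), a step of similar size is expected from compound 2 to compound 4, namely no change at the digits printed from compound 2 to compound 4 (within the scatter) in this assay. Compound 4 is therefore estimated to give 104% in this assay, expected between 93% and 115%.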

Compound 4, a percentage reported as activity, at one concentration (the size of the read-out at that concentration, not a potency): 98%
Compound 4: middle estimate off by 6 percentage points, on the high side, and the stated range covers the measured number.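

In this assay, putting acetyl in place of methoxy on an aromatic carbon gives a number 6 percentage points lower from compound 2 to compound 4 (within the scatter), so the swap has now been seen on two cores and neither step stands out from the normal spread of repeat measurements. Set side by side, the two steps cannot be told apart: the same change on two cores in this assay, a number 2 percentage points higher (within the scatter) from compound 1 to compound 3 and a number 6 percentage points lower (within the scatter) from compound 2 to compound 4, 8 percentage points apart, within the scatter of two such steps. This shows that, so far, carrying the change from one core to the other has produced no difference that can be distinguished from scatter, but it does not show that the change is truly without effect or that it would behave alike on every core, since steps this small can hide a real but modest shift.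

The compounds shown leave open whether a different group at this place, such as an amine or a carboxylic acid, would move the number beyond the scatter. They also leave open whether a longer chain in place of the acetyl would do so on either core.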